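Three Amides Without Measurable Cytotoxicity, and a Fourth

The compounds below may be only part of what the source reports. "The series", "measured", "known", "first", "only" and "open" are said of these compounds alone.

Measured so far, in a functional assay on HeLa cells (Homo sapiens) for cytotoxicity, read by MTT assay, with a stated time of 24 h; on this read-out higher numbers stand for weaker inhibition and lower numbers for stronger inhibition:
- compound 1 `C=CC1=C(C(=O)Nc2ccccc2OC)C(c2ccc(F)cc2)OC1`; compound 1 reaches only a limit, > 100000 nM
- compound 2 `C=CC1=C(C(=O)NC(C)(C)C)C(c2ccc(OC)cc2)OC1`; compound 2 likewise reaches only a limit, > 100000 nM
- compound 3 `C=CC1=C(C(=O)NCCC)C(c2ccc(OC)c(OC)c2)OC1`; compound 3 likewise reaches only a limit, > 100000 nM

Within the data shown here, compound 1 stands nowhere in particular on these numbers: it sits at the limit of > 100000 nM in this assay, at which 3 of the 3 values shown sit, and so no ordering among the three can be read, and no step between measured compounds can be sized. All three share the same core and differ in the group on the amide nitrogen and in the substituents on the aryl ring, yet none of these changes brought any of them below the limit.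

Compound 4 `C=CC1=C(C(=O)NCc2ccc(C)cc2)C(c2ccc(F)cc2)OC1` differs from compound 1 in one place: 4-methylbenzyl in place of 2-methoxyphenyl on an amide-type nitrogen.

With every measured companion at the limit (the limit of > 100000 nM in this assay, at which 3 of the 3 values shown sit), this change is expected to give a step that the limit leaves unreadable from compound 1 to compound 4 in this assay, that is nothing beyond the usual scatter. Compound 4 is therefore expected to give about 150000 nM, with a range from 40000 nM to 600000 nM, most probably reported again only as a limit.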

Compound 4, half-maximal inhibitory concentration: > 100000 nM
Compound 4: no number, only a limit; the forecaster's own chance of this, stated with the estimate: 80%; the middle value lies beyond the limit too.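

In this assay, among these compounds, compound 4 gives > 100000 nM, which is a limit and not a number; compound 1 also reaches only a limit, so no step between the two can be read. The compounds shown leave open whether any change on this shared core gives measurable cytotoxicity.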